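Sulfonyl aryl change from compound 2 to compound 3

A few compounds are considered here, and "the series" means these few. Any claim that something is new, unique, unknown or untested is made for them only; others in the source may bear on it.

Measured in a functional assay on MCF7 cells (Homo sapiens) for antiproliferative activity, read by MTT assay, with a stated time of 24 h; on this read-out lower numbers stand for stronger inhibition and higher numbers for weaker inhibition:
- compound 1 `Cc1ccc(-c2nn(-c3ccccc3)cc2-c2nc3ccccc3n2S(=O)(=O)c2ccc(F)cc2)cc1`: 5270 nM
- compound 2 `COc1ccc(S(=O)(=O)n2c(-c3cn(-c4ccccc4)nc3-c3ccc(F)cc3)nc3ccccc32)cc1`: 530 nM

Compound 2 holds the lower of the two numbers, and its gap to compound 1 lies beyond the usual scatter. These two compounds differ in more than one place, so that gap cannot be tied to a single change. The unmeasured compound 3 `O=S(=O)(c1ccc(Cl)cc1)n1c(-c2cn(-c3ccccc3)nc2-c2ccc(F)cc2)nc2ccccc21` departs from compound 2 in one place: 4-methoxyphenyl becomes 4-chlorophenyl, with chloro in place of methoxy on an aromatic carbon, para to a large group (chloro in place of methoxy on an aromatic carbon). Within the data shown here, no measured pair shows this change, so the expectation is loose. It is anchored on compound 2 at 530 nM, with compound 1 at 5270 nM as the only other reference. A moderate move toward weaker inhibition in this assay is expected, a 2.3-fold higher number from compound 2 to compound 3 (0.35 log units; beyond the scatter). Compound 3 is estimated at 1200 nM, with an expected range of 350 nM to 4000 nM.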

Compound 3, half-maximal inhibitory concentration: 4960 nM
The estimate for compound 3 lay 4.1-fold (0.62 log units) below the measured number, outside the stated range (above it).
By their numbers in this assay, from the lowest: compound 2; then compounds 3 and 1 (each within the scatter of the next).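

In this assay, among these compounds, the sulfonyl aryl ring gives the first single-place reading: chloro in place of methoxy on an aromatic carbon, para to a large group, gives a 9.4-fold higher number from compound 2 to compound 3 (0.97 log units; beyond the scatter) with the rest of the structure unchanged. The earlier pair differed in more than one place, whereas this step ties a gap beyond the scatter to this one position, where the substituent clearly matters and methoxy holds the lower number. No measurement shown accounts for the size of this step.

From the compounds shown here alone, it remains open whether the step reflects the loss of methoxy or the entry of chloro, and a single pair gives no trend across substituents. An amine, a carboxylic acid or a longer alkoxy chain on the same carbon would show how far this position tolerates change.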